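This account rests on a few compounds, and the source may have more. Where it says the series, first, only, none or still open, it means among the compounds named here.

Measured compounds:
Compound 1 `CNC(=O)c1cc(C(=O)NC2CC2)cn([C@H](C)c2ccccc2)c1=O`: 3.4
Compound 2 `CNC(=O)c1cc(C(=O)NC2CCOCC2)cn(Cc2ccccc2)c1=O`: 2.8
Compound 3 `CNC(=O)c1cc(C(N)=O)cn(Cc2ccccc2)c1=O`: 2

In a physicochemical assay for lipophilicity, at pH 7.4 (on this read-out lower numbers stand for lower lipophilicity and higher numbers for higher lipophilicity), compound 1 stands highest of the three measured numbers; compound 2 is nearest, and compound 3 furthest, both beyond the scatter. For the measured compounds named here, the only step measured within one change of structure is a number 0.80 log units lower from compound 2 to compound 3 (beyond the scatter); it is the one measured step that involves an oxan-4-yl ring, and it concerns an amide-type nitrogen rather than the aromatic nitrogen.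

Compound 4 `CNC(=O)c1cc(C(=O)NC2CC2)cn(CC2CCOCC2)c1=O` is not yet measured. Relative to compound 1 the change is (oxan-4-yl)methyl in place of 1-phenylethyl on an aromatic nitrogen. Going by the values given here, no measured step shows a phenyl-containing group exchanged for an oxane-containing group on the aromatic nitrogen, so the expectation rests on the general direction seen in a number 0.80 log units lower from compound 2 to compound 3 (beyond the scatter) and on the counted loss of the aromatic ring with entry of an oxygen-containing ring. A step downward beyond the scatter is expected, larger than that measured step. Compound 4 is therefore estimated at 2.1, within 1.5 to 2.7, an expected step of a number 1.30 log units lower from compound 1 to compound 4 (beyond the scatter).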

Compound 4, distribution coefficient: 1.5
Compound 4: the middle estimate sits 0.60 log units above what was measured, and the stated range covers the measured number.
By their numbers in this assay, from the lowest: compound 4; then compound 3; then compound 2; then compound 1.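

For the compounds shown here, on the aromatic nitrogen, (oxan-4-yl)methyl in place of 1-phenylethyl gives a number 1.90 log units lower from compound 1 to compound 4 (beyond the scatter) in this assay, so this position carries a large step, whereas the only earlier step, a number 0.80 log units lower from compound 2 to compound 3 (beyond the scatter), was modest and sat on an amide-type nitrogen. The change exchanges a six-membered aromatic ring of carbon only for a six-membered non-aromatic ring with 1 hetero atom, brings in a hydrogen-bond acceptor and removes the defined stereocentre, all in one step, so the size of the step cannot be divided among these features. Nothing measured on these compounds explains the size of this step.

The compounds shown leave open how much of the step goes with the ring oxygen and how much with the loss of the aromatic ring, which a cyclohexylmethyl group on the same nitrogen would separate. Also open, on these data alone, is how a piperidin-4-ylmethyl group, which carries an amine, or a longer chain ending in a carboxylic acid would read in this assay at this position.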